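This account rests on a few compounds, and the source may have more. Where it says the series, first, only, none or still open, it means among the compounds named here.

Compound 3, `CC(C)(C)c1cc(NC(=O)[C@@H]2CCCCN2C(=O)N2CCCCC2)no1`, is tested in a physicochemical assay for solubility, read by HPLC, at pH 6.8 (a lower number here means a less soluble compound, a higher number a more soluble compound), where compound 3 gives 49 ug/mL. Of the two numbers shown in this assay, compound 3 has the lower one, and its nearest neighbour is compound 2, `CC(C)(C)c1cc(NC(=O)[C@@H]2CCCCN2C(=O)CC2CCOCC2)no1`, which in this assay gives 52 ug/mL; the gap a 1.1-fold lower number from compound 2 to compound 3 (0.03 log units; within the scatter) lies within the scatter, so the two compounds cannot be ordered. Compound 1, `CC(C)(C)c1cc(NC(=O)[C@@H]2CCCCN2C(=O)c2ccc(Cl)cc2)no1`, returns only a limit in this assay, < 0.1 ug/mL. That limit is the limit of < 0.1 ug/mL in this assay, at which 1 of the 3 values shown sits. From compound 1 the two steps made so far are both large: an at least 520-fold higher number from compound 1 to compound 2 (2.71 log units; beyond the scatter) and an at least 490-fold higher number from compound 1 to compound 3 (2.69 log units; beyond the scatter).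

Compound 4, `CC(C)(C)c1cc(NC(=O)[C@@H]2CCCCN2C(=O)N2CCSCC2)no1`, differs from compound 3 in one place: thiomorpholin-4-yl in place of piperidin-1-yl on a carbonyl carbon. Among the compounds with values here, no measured step changes a carbonyl substituent in this way; the only measured step between two saturated groups on that carbonyl, a 1.1-fold lower number from compound 2 to compound 3 (0.03 log units; within the scatter), stayed within the scatter. For the step from compound 3 to compound 4 in this assay, a change within the scatter is therefore expected, and compound 4 is estimated to give 60 ug/mL, within a range of 25 ug/mL to 140 ug/mL, which means an expected step of a 1.2-fold higher number from compound 3 to compound 4 (0.09 log units; within the scatter).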

Compound 4, solubility: 46 ug/mL
The estimate for compound 4 lay 1.3-fold (0.12 log units) above the measured number; measured number inside the range.
By their numbers in this assay, from the lowest: compounds 4, 3 and 2 (each within the scatter of the next). At a limit, below all of these: compound 1.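

In this assay, the hetero atom count of the six-membered ring on the carbonyl carbon rises with thiomorpholin-4-yl, which carries a ring sulfur and one hydrogen-bond acceptor where piperidin-1-yl has none, yet this exchange stays within the scatter (a 1.1-fold lower number from compound 3 to compound 4 (0.03 log units; within the scatter)). The same holds against the (oxan-4-yl)methyl group (a 1.1-fold lower number from compound 2 to compound 4 (0.05 log units; within the scatter)), so compounds 2, 3 and 4 now form a set of three saturated groups on this carbonyl that cannot be ordered in this assay, where earlier there were only two. All three stand well clear of the 4-chlorophenyl compound (an at least 460-fold higher number from compound 1 to compound 4 (2.66 log units; beyond the scatter)), though that step starts from a reading that is a limit and gives only a bound on its size: the limit of < 0.1 ug/mL in this assay, at which 1 of the 4 values shown sits.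

The compounds shown leave open whether a basic ring such as 4-methylpiperazin-1-yl, or morpholin-4-yl, on the same carbonyl would also stay level with these three in this assay. They also leave open which part of 4-chlorophenyl goes with the limit, since a plain phenyl or a pyridinyl group would be needed to separate the chlorine from the ring.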